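The source may hold more compounds than are shown below. What is called first, only, known or untested is meant among the compounds shown, and "the series" means these compounds.

Measured compounds in a functional assay on MDA-MB-231 cells (Homo sapiens) for cytotoxicity, read by MTT assay, with a stated time of 72 h; on this read-out lower numbers stand for stronger inhibition and higher numbers for weaker inhibition:
compound 1 `CN(C)CCNc1nc(-c2ccc(NC(=O)Nc3ccccc3)cc2)nc2ccsc12` gives 1310 nM
compound 2 `CN(C)CCNc1nc(-c2ccc(NC(=O)Nc3ccccc3Cl)cc2)nc2c(Cl)c(Cl)sc12` gives 1350 nM
compound 3 `CCN(CC)CCCNc1nc(-c2ccc(NC(=O)Nc3ccccc3)cc2)nc2ccsc12` gives 1230 nM

On these numbers compound 3 stands alongside compound 1 and compound 2: its value differs from each of theirs by less than the usual scatter, so the three cannot be told apart. Compound 4 `CCN(CC)CCCNc1nc(-c2ccc(NC(=O)Nc3ccccc3F)cc2)nc2ccsc12` has not been measured. It differs from compound 3 by fluoro in place of hydrogen on an aromatic carbon, on an aromatic carbon of a six-membered aromatic ring of carbon only, ortho to a large group. Among the compounds with values here, the only single-change step recorded, a 1.1-fold lower number from compound 1 to compound 3 (0.03 log units; within the scatter), concerns the amine chain and not this ring, and it was within the scatter. Compound 2, which carries chloro on the same ring together with two chlorines on the core, gives a value within the scatter of compound 1, so nothing in the data points to a shift from a small substituent on this ring. Compound 3 to compound 4 is therefore expected to show no step beyond the scatter, a 1.0-fold lower number from compound 3 to compound 4 (0.01 log units; within the scatter). Compound 4 is estimated at 1200 nM, with a range from 600 nM to 2500 nM.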

Compound 4, half-maximal inhibitory concentration: 860 nM
For compound 4 the middle estimate is 1.4-fold (0.14 log units) above the measured one; the range from low to high includes it.
By their numbers in this assay, from the lowest: compounds 4, 3, 1 and 2 (each within the scatter of the next).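

In this assay, fluoro in place of hydrogen on an aromatic carbon gives a 1.4-fold lower number from compound 3 to compound 4 (0.16 log units; within the scatter), a step that stays within the scatter. Within the data shown here, this is the first single-change step on this six-membered aromatic ring of carbon only: the earlier step concerned the amine chain, and compound 2 differs from compound 1 in more than one place. It shows that phenyl to 2-fluorophenyl, ortho to a large group, gives no change that can be separated from the scatter, and no measurement at hand offers an explanation for the size of this step.

The compounds shown leave open whether a methoxy or trifluoromethyl group at this place would give a step beyond the scatter. They also leave open how chloro alone on this ring would read, without the two chlorines on the core.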